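Compound 2 to compound 4: thiophen-2-yl for 2-chlorophenyl

This account rests on a few compounds, and the source may have more. Where it says the series, first, only, none or still open, it means among the compounds named here.

Compound 1 `C[C@H](Nc1cccc(OCc2ccccc2)c1)C(N)=O` gives 79.7 mg/kg
Compound 2 `C[C@@H](NCc1ccc(OCc2ccccc2Cl)cc1)C(N)=O` gives 17.4 mg/kg
Compound 3 `CNC(=O)[C@@H](CO)NCc1ccc(OCc2ccccc2F)cc1` gives 12.4 mg/kg

All three numbers come from a functional assay on the whole organism with Mus musculus as the target (a lower number here means that less compound is needed, a higher number that more compound is needed for the effect), as the shared read-out. Compound 2 at 17.4 mg/kg sits within the scatter of compound 3 and beyond the scatter from compound 1, which has the higher number. Compound 4 `C[C@@H](NCc1ccc(OCc2cccs2)cc1)C(N)=O` carries thiophen-2-yl in place of 2-chlorophenyl on a saturated chain carbon bound to an oxygen on an aromatic ring on a saturated chain carbon bound to an oxygen on an aromatic ring, with thiophen-2-yl in place of 2-chlorophenyl. For the measured compounds named here, no measured pair differs in one place, so the data give no direct precedent for this change. Without such a precedent, no step beyond the scatter is expected. The estimated step of a 1.3-fold higher number from compound 2 to compound 4 (0.10 log units; within the scatter) is expected to stay within the scatter, toward a slightly higher number. For compound 4 the estimate is 22 mg/kg with an expected range from 9 mg/kg to 50 mg/kg in this series.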

Compound 4, dose for half-maximal effect: 61.6 mg/kg
Compound 4: middle estimate off by 2.8-fold (0.45 log units), on the low side; measured number outside the range, above it.
By their numbers in this assay, from the lowest: compounds 3 and 2 (each within the scatter of the next); then compounds 4 and 1 (each within the scatter of the next).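

In this assay, thiophen-2-yl in place of 2-chlorophenyl on a saturated chain carbon bound to an oxygen on an aromatic ring gives a 3.5-fold higher number from compound 2 to compound 4 (0.55 log units; beyond the scatter). For the compounds shown here, this is the first one-place comparison, and it shows that the group at this position matters: with thiophen-2-yl, more compound is needed for the effect. No supporting data bear on the cause of this step.

Still open, as far as these compounds go, is whether the step tracks the loss of the chlorine or the change of ring. Furan-2-yl or 3-chlorophenyl at this place would help separate the two.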